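The compounds below may be only part of what the source reports. "The series", "measured", "known", "first", "only" and "open" are said of these compounds alone.

Within the data shown here, in an ADME assay on K562 cells (Homo sapiens) for antiproliferative activity, with a stated time of 72 h (on this read-out lower numbers stand for stronger inhibition of growth and higher numbers for weaker inhibition of growth), compound 3 `Cc1ccc(CNc2nc(=O)c3cc(C(F)(F)F)cc([N+](=O)[O-])c3s2)n1C` gives 21000 nM, the only single number among the three compounds measured there. Compound 1 `COC(=O)[C@@H]1OC2(CCN(c3nc(=O)c4cc(C(F)(F)F)cc([N+](=O)[O-])c4s3)CC2)O[C@H]1c1ccccc1` reaches only a limit of the assay, > 50000 nM; this is the limit of > 50000 nM in this assay, at which 1 of the 3 values shown sits. For compound 2 `O=c1nc(N2CCC(F)(F)CC2)sc2c([N+](=O)[O-])cc(C(F)(F)F)cc12` no result was reported in this assay, the entry standing as "not determined" (no result reported). Compound 4 `O=c1nc(NCc2ccc3c(c2)OCCO3)sc2c([N+](=O)[O-])cc(C(F)(F)F)cc12` remains to be measured in this assay; it differs from compound 3 by 2,3-dihydro-1,4-benzodioxin-6-yl in place of 1,5-dimethyl-1H-pyrrol-2-yl on a saturated chain carbon bound to a nitrogen on an aromatic ring. Among the measured compounds shown here, no measured pair differing in one place is available to gauge such a change, so the expected step of a 1.2-fold lower number from compound 3 to compound 4 (0.07 log units; within the scatter) is estimated to lie within the usual scatter, with no direction favoured. Compound 4 is therefore expected to give about 18000 nM in this assay, with a likely range from 6000 nM to 50000 nM.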

Compound 4, concentration for 50% growth inhibition: 37000 nM
The estimate for compound 4 lay 2.1-fold (0.31 log units) below the measured number; measured number inside the range.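

In this assay the exchange gives a 1.8-fold higher number from compound 3 to compound 4 (0.25 log units; within the scatter) as the first step read between compounds differing in one place. On the saturated chain carbon bound to a nitrogen on an aromatic ring, 2,3-dihydro-1,4-benzodioxin-6-yl and 1,5-dimethyl-1H-pyrrol-2-yl therefore cannot be told apart, even though their rings differ. Nothing shown gives a cause for this step.

On these data alone, whether a simple phenyl, a pyridine or a carboxylic acid at this place would move the number beyond the scatter stays open. So does the effect of changing the nitro or trifluoromethyl group on the shared core.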